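A Hydroxy Group Moved Along the Seven-Membered Ring

The source may report more compounds than this note shows. Statements on the series, on what has been measured and on what is new or still open speak of the compounds shown alone.

Compound 1 `C=C1C(=O)O[C@@H]2[C@@H]1CC[C@H](C)[C@@](O)(C(=O)/C=C/C)[C@H]2OC(=O)/C(C)=C\C` is the parent of this small series. In a functional assay on BC1 cells (Homo sapiens) for cytotoxicity (on this read-out lower numbers stand for an effect already at smaller amounts and higher numbers for an effect only at larger amounts of compound), compound 1 gives 0.8 ug/mL, the higher of the two numbers recorded, though the other number lies within the scatter of it. Compound 2 `C=C1C(=O)O[C@@H]2[C@@H]1C[C@@H](O)[C@H](C)[C@@](O)(C(=O)/C=C/C)[C@H]2OC(=O)/C(C)=C\C`, which carries a hydroxy in place of hydrogen on a saturated ring carbon, gives 0.6 ug/mL in this assay; the step of a 1.3-fold lower number from compound 1 to compound 2 (0.12 log units; within the scatter) is within the scatter of this read-out. Compound 3 `C=C1C(=O)O[C@@H]2[C@@H]1[C@@H](O)C[C@H](C)[C@@](O)(C(=O)/C=C/C)[C@H]2OC(=O)/C(C)=C\C` has not yet been measured. It differs from compound 1 by hydroxy in place of hydrogen on a saturated ring carbon. For the measured compounds named here, the only measured step that bears on this change is a 1.3-fold lower number from compound 1 to compound 2 (0.12 log units; within the scatter), in which the same kind of substitution at another saturated ring carbon produced no shift beyond the scatter. On that basis no change beyond the scatter is expected from compound 1 to compound 3, an expected step of no change at the digits printed from compound 1 to compound 3 (within the scatter). Compound 3 is therefore estimated at 0.8 ug/mL, within a range from 0.4 ug/mL to 1.6 ug/mL.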

Compound 3, concentration for half-maximal effect: 4.2 ug/mL
For compound 3 the middle estimate is 5.3-fold (0.72 log units) below the measured one, outside the stated range (above it).
By their numbers in this assay, from the lowest: compounds 2 and 1 (each within the scatter of the next); then compound 3.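

In this assay, hydroxy in place of hydrogen proves not to be a neutral change everywhere on the seven-membered ring: at the saturated ring carbon next to the ring atom that bears a fused ring, it gives a 5.3-fold higher number from compound 1 to compound 3 (0.72 log units; beyond the scatter) and this step lies beyond the scatter. The earlier substitution, a 1.3-fold lower number from compound 1 to compound 2 (0.12 log units; within the scatter) and within the scatter, had shown no such shift, so in these two cases the outcome depends on which ring carbon carries the hydroxy. Nothing given here accounts for this difference.

The compounds shown leave open whether the shift is particular to hydroxy, as an amine or a methoxy group on the same carbon would test. They also leave open whether the opposite orientation of the hydroxy at this carbon would give a similar number.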